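Phenoxy for Phenyl on the Shared Core

The compounds below may be only part of what the source reports. "The series", "measured", "known", "first", "only" and "open" are said of these compounds alone.

Compound 1 `CCOC(=O)c1cnc(-c2ccccc2)nc1NN1C(=O)C=C(C)C1=O` gives 100 nM in a functional assay on Jurkat cells for inhibition of nuclear factor NF-kappa-B complex (Homo sapiens) (on this read-out lower numbers stand for stronger inhibition and higher numbers for weaker inhibition), the lowest of the three numbers measured. Compound 2 `CCOC(=O)c1cnc(-c2cccc(Br)c2)nc1NN1C(=O)C=C(C)C1=O` gives 700 nM and compound 3 `CCOC(=O)c1cnc(C2CC2)nc1NN1C(=O)C=C(C)C1=O` gives 1000 nM. Compound 4 `CCOC(=O)c1cnc(Oc2ccccc2)nc1NN1C(=O)C=C(C)C1=O` is not yet measured; it differs from compound 1 as follows: phenoxy in place of phenyl on an aromatic carbon. Going by the values given here, two measured steps touch the same place: a 7.0-fold higher number from compound 1 to compound 2 (0.85 log units; beyond the scatter), and a 10-fold higher number from compound 1 to compound 3 (1.00 log units; beyond the scatter). Both changes at this carbon gave weaker inhibition, so a step in the same direction is expected for compound 4, though the retained aromatic ring may keep it smaller than that of compound 3. Compound 4 is therefore estimated at 300 nM, within 100 nM to 1500 nM, which means an expected step of a 3.0-fold higher number from compound 1 to compound 4 (0.48 log units; beyond the scatter).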

Compound 4, half-maximal inhibitory concentration: 15000 nM
Compound 4: middle estimate off by 50-fold (1.70 log units), on the low side; measured number outside the range, above it.
By their numbers in this assay, from the lowest: compound 1; then compounds 2 and 3 (each within the scatter of the next); then compound 4.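

The retained aromatic ring did not hold inhibition at this carbon: in this assay phenoxy for phenyl gave a 150-fold higher number from compound 1 to compound 4 (2.18 log units; beyond the scatter) and so a much larger loss than either earlier change here. Compound 4 also falls well behind the two weaker earlier compounds, with a 15-fold higher number from compound 3 to compound 4 (1.18 log units; beyond the scatter) and with a 21-fold higher number from compound 2 to compound 4 (1.33 log units; beyond the scatter) as well, so at this carbon the phenoxy group is the poorest of the four groups shown. Nothing measured here bears on what lies behind this drop.

Going by these compounds, whether an anilino or a benzyl group at this carbon would behave like phenyl or like phenoxy remains open.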